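Two Methyl Groups Added to a Weakly Active Sulfonamide

The source may hold more compounds than are shown below. What is called first, only, known or untested is meant among the compounds shown, and "the series" means these compounds.

Three compounds share one core and differ only in the group carried on the sulfonamide nitrogen. In a functional assay on HeLa cells (Homo sapiens) for antiproliferative activity, read by sulforhodamine B assay, with a stated time of 48 h (on this read-out higher numbers stand for weaker inhibition and lower numbers for stronger inhibition), compound 1 `N=C(N)NS(=O)(=O)c1ccc(N/C(S)=N\c2ccnc3cc(C(F)(F)F)ccc23)cc1` gives 23900 nM, a weak result. Compound 2 `Cc1noc(NS(=O)(=O)c2ccc(N/C(S)=N\c3ccnc4cc(C(F)(F)F)ccc34)cc2)c1C` was reported as "not active" (no number reported) in this assay, with no number given. Compound 3 `O=S(=O)(Nc1ncccn1)c1ccc(N/C(S)=N\c2ccnc3cc(C(F)(F)F)ccc23)cc1` likewise was reported as "not active" (no number reported) in this assay, so no number stands for it; it sits beside compound 2 as the second entry without a value, and both fall behind compound 1.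

Compound 4 `Cc1cc(C)nc(NS(=O)(=O)c2ccc(N/C(S)=N\c3ccnc4cc(C(F)(F)F)ccc34)cc2)n1` differs from compound 3 by one change: 4,6-dimethylpyrimidin-2-yl in place of pyrimidin-2-yl on a sulfonamide nitrogen. Among the measured compounds shown here, no measured pair in this set shows what such a change does, so no step beyond the usual scatter is expected in either direction. Given that compound 3 shows no measurable inhibition, compound 4 is expected to remain weak, with an estimated value of 30000 nM in this assay, within a range from 8000 nM to 100000 nM, and a strong chance that only inactivity is reported again.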

Compound 4, half-maximal inhibitory concentration: 33000 nM
Compound 4: middle estimate off by 1.1-fold (0.04 log units), on the low side; the measured number falls inside the stated range.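

In this assay compound 4 gives a number where compound 3, with pyrimidin-2-yl on the sulfonamide nitrogen, was reported only as not active, so the size of this change cannot be read. The values show a 1.4-fold higher number from compound 1 to compound 4 (0.14 log units; within the scatter) and so place the 4,6-dimethylpyrimidin-2-yl group and the far smaller group of compound 1 level on this nitrogen, both with weak results. Nothing measured here explains why the dimethyl version yields a number when pyrimidin-2-yl did not.

The compounds shown leave open whether a single methyl group on the pyrimidin-2-yl ring would be enough to give a number. They also leave open what a plain phenyl ring or an acetyl group would do on this sulfonamide nitrogen.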